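Ethyl Ester of a Pyrazine-Carboxylate Cinnamic Acid

The compounds below may be only part of what the source reports. "The series", "measured", "known", "first", "only" and "open" are said of these compounds alone.

Measured compounds:
compound 1 `COc1cc(/C=C/C(=O)O)ccc1OC(=O)c1nc(C)c(C)nc1C`: 49.1%
compound 2 `COc1cc(/C=C/C(=O)O)cc(OC)c1OC(=O)c1nc(C)c(C)nc1C`: 96.6%

For the measured compounds named here, in a functional assay on EA.hy 926 cells (Homo sapiens) for cytotoxicity, read by MTT assay, with stated times of 24 h and 12 h, tested at 50 uM (on this read-out higher numbers stand for a stronger effect at the one concentration tested and lower numbers for a weaker effect), compound 2 gives 96.6%, the highest of the two numbers; compound 1 gives 49.1%, and the one measured step, a number 47.5 percentage points higher from compound 1 to compound 2 (beyond the scatter), is large and beyond the scatter. Compound 3 `CCOC(=O)/C=C/c1cc(OC)c(OC(=O)c2nc(C)c(C)nc2C)c(OC)c1` differs from compound 2 by ethyl in place of hydrogen on an oxygen next to a carbonyl group. Going by the values given here, the only measured step concerns a methoxy on an aromatic carbon and does not touch the carboxy, so no measured step bears on this change. Among the compounds with values here, the expectation for compound 3 therefore rests on compound 2 alone, and with no step of its own kind to lean on, compound 3 is expected to show a number 8.6 percentage points lower from compound 2 to compound 3 (within the scatter), that is no step beyond the scatter in this assay. Compound 3 is thus estimated at 88%, within a range from 60% to 100%.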

Compound 3, a percentage reported as activity, at one concentration (the size of the read-out at that concentration, not a potency): -13.6%
Estimate against measurement, compound 3: 101.6 percentage points above; measured number below the stated range.
By their numbers in this assay, from the lowest: compound 3; then compound 1; then compound 2.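

The earlier step concerned only a methoxy on an aromatic carbon. This one shows that the read-out in this assay also answers to a change at the carboxy, where ethyl in place of hydrogen on an oxygen next to a carbonyl group gives a number 110.2 percentage points lower from compound 2 to compound 3 (beyond the scatter). Within this pair, the strong effect at the one concentration tested therefore goes with the free carboxy and is lost in the ethoxycarbonyl form, while nothing at hand bears on why the number falls.

The compounds shown leave open whether the loss belongs to ethyl itself or to any replacement of that hydrogen, which a methyl ester, a primary amide or a longer chain on that oxygen would help to separate. They also leave open whether the same change would act alike on compound 1, which carries one methoxy fewer.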